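Chloro for hydrogen, starting from the limit of compound 3

The source may hold more compounds than are shown below. What is called first, only, known or untested is meant among the compounds shown, and "the series" means these compounds.

In a functional assay on KB cells (Homo sapiens) for inhibition (a higher number here means a weaker inhibitor, a lower number a stronger inhibitor), compound 1 (`Nc1nc2cc(Cl)c(Cl)cc2n1Cc1ccccc1`) gives 170000 nM and compound 2 (`Nc1nc2cc(Cl)c(Cl)cc2n1Cc1ccc(Cl)cc1`) gives 45000 nM.

Compound 3 (`Clc1cc2nc(Cl)n(Cc3ccccc3)c2cc1Cl`) is recorded at > 100000 nM, which is a limit of the assay and not a number. The replacement of amino by chloro is therefore a step that the limit leaves unreadable from compound 1 to compound 3.

Compound 4 (`Clc1ccc(Cn2c(Cl)nc3cc(Cl)c(Cl)cc32)cc1`) carries one change: chloro in place of hydrogen on an aromatic carbon, a chloro in place of hydrogen on an aromatic carbon, para to a large group.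

Among the measured compounds shown here, the one measured step of the same kind is a 3.8-fold lower number from compound 1 to compound 2 (0.58 log units; beyond the scatter), a modest gain beyond the scatter. Its size rests on a single pair, and that pair carries amino where compound 3 carries chloro, so its transfer is uncertain. A similar modest move toward a lower number is expected in this assay, from a starting point known only as a limit.

The expected change is an at least 2.0-fold lower number from compound 3 to compound 4 (0.30 log units; that floor lies within the scatter).

For compound 4 the estimated value is 50000 nM, with an expected range of 20000 nM to 130000 nM.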

Compound 4, half-maximal inhibitory concentration: > 100000 nM
Compound 4 was reported as a limit; the forecaster's own chance of this, stated with the estimate: 30%; at least 2.0-fold (0.30 log units) between middle value and limit.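

In this assay compound 4 stands at > 100000 nM, which is a limit of the assay and not a number. The steps from compound 1 to compound 3 and from compound 3 to compound 4 cannot be read, because the values that would size them sit at a shared limit: the limit of > 100000 nM in this assay, at which 2 of the 4 values shown sit.

Among the compounds shown here, with chloro fixed para to a large group, the change of amino to chloro does read, as an at least 2.2-fold higher number from compound 2 to compound 4 (0.34 log units; beyond the scatter), the first sized evidence that losing the amino group raises the number.

As far as these compounds go, whether chloro para to a large group lowers the number at all when chloro replaces amino remains open. Also open, from the compounds shown here alone, is how a methylamino or hydroxyl group in place of amino, or a methoxy group in place of that chloro, would behave.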